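The source may hold more compounds than are shown below. What is called first, only, known or untested is meant among the compounds shown, and "the series" means these compounds.

Compound 1 `COc1ccc(C2(OC(C)C)SC=C(C)n3c2noc3=O)cc1` gives 430 nM in a functional assay (Left cardiac atrium, Cavia porcellus), with a stated time of 30 min; a higher number here means that more compound is needed for the effect, a lower number that less compound is needed
Compound 2 `COc1cccc(C2(O)SC=C(C)n3c2noc3=O)c1` gives 490 nM in this assay

These two numbers lie within the usual scatter of repeated measurements, so compound 2 stands level with compound 1, and neither can be called the better of the pair. Within the data shown here, the two values offer no measured step between compounds that differ in one place.

The next compound is compound 3 `COc1cccc(C2(OCC(F)(F)F)SC=C(C)n3c2noc3=O)c1`, which has not yet been measured. It keeps the rest of compound 2 and makes one change, (2,2,2-trifluoroethyl in place of hydrogen on an oxygen on a saturated carbon), namely 2,2,2-trifluoroethyl in place of hydrogen on an oxygen on a saturated carbon. Cut one bond further out, the same change reads hydroxy to 2,2,2-trifluoroethoxy. Among the measured compounds shown here, no measured pair shows what this change does, so any forecast must stay broad. In this assay, no shift beyond the scatter is expected in either direction, and the estimated step is a 1.1-fold lower number from compound 2 to compound 3 (0.04 log units; within the scatter). For compound 3 the expected value is 450 nM, with an estimated range from 150 nM to 1400 nM.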

Compound 3, half-maximal effective concentration: 320 nM
The estimate for compound 3 lay 1.4-fold (0.15 log units) above the measured number; the range from low to high includes it.
By their numbers in this assay, from the lowest: compounds 3, 1 and 2 (each within the scatter of the next).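

In this assay, placing 2,2,2-trifluoroethyl in place of hydrogen on an oxygen on a saturated carbon gives a 1.5-fold lower number from compound 2 to compound 3 (0.19 log units; within the scatter) and so leaves the compounds level. Among these compounds, this is the first measured single change at this position, and it shows that a hydroxy group can be swapped for the much larger 2,2,2-trifluoroethoxy group without a shift that can be told apart from ordinary assay scatter. No measurement shown here accounts for this outcome, so the result can be recorded but not explained.

This one pair cannot show whether the fluorine atoms matter, and a plain ethoxy group on the same carbon, set beside compound 3, would address that question directly. From the compounds shown here alone, how far this tolerance extends also remains open, since a longer chain such as n-butoxy, or an amine or a carboxylic acid carried on the same oxygen-bearing carbon, might either stay level with compound 2 in this assay or move well beyond the scatter.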